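Sulfonyl aryl swap in the shared core series

This account rests on a few compounds, and the source may have more. Where it says the series, first, only, none or still open, it means among the compounds named here.

Within the data shown here, compound 2 `Cc1cccc(S(=O)(=O)N2CCC(N3CCC(C)CC3)CC2)c1` holds the lowest of the two numbers so far: in a functional assay on DLD-1 cells (Homo sapiens) for antiproliferative activity, read by CellTiter-Glo, with a stated time of 72 h (a lower number here means a stronger inhibitor, a higher number a weaker inhibitor), compound 2 gives 25 nM, while compound 1 `CC1CCN(C2CCN(S(=O)(=O)c3ccc(F)cc3F)CC2)CC1` gives 102 nM. Among the measured compounds shown here, the single measured step, a 4.1-fold lower number from compound 1 to compound 2 (0.61 log units; beyond the scatter), is the only change of the aryl group on the sulfonyl sulfur and so bears directly on compound 3 `CC1CCN(C2CCN(S(=O)(=O)c3ccc(Cl)c(Cl)c3)CC2)CC1`, which differs from compound 2 by 3,4-dichlorophenyl in place of 3-methylphenyl on a sulfonyl sulfur. For the measured compounds named here, that step was modest, and no measured pair carries a chlorinated aryl. Compound 3 is therefore expected to move little from that level, the estimated step of a 1.4-fold higher number from compound 2 to compound 3 (0.15 log units; within the scatter) lying within the scatter or just beyond it. Compound 3 is estimated at 35 nM, with a range of 12 nM to 100 nM.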

Compound 3, half-maximal inhibitory concentration: 2.9 nM
Beside the measured number, compound 3's estimate is 12-fold (1.08 log units) above it, and the stated range ends above it.
By their numbers in this assay, from the lowest: compound 3; then compound 2; then compound 1.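

The aryl group on the sulfonyl sulfur sets a wider range in this assay than the first step showed: 3,4-dichlorophenyl in place of 3-methylphenyl gives an 8.6-fold lower number from compound 2 to compound 3 (0.94 log units; beyond the scatter) and, in place of 2,4-difluorophenyl, a 35-fold lower number from compound 1 to compound 3 (1.55 log units; beyond the scatter) as the larger change. Compound 3, the only one with a chlorinated aryl, now has the lowest number, and both of its steps lie beyond the scatter. Nothing available accounts for the size of these steps.

The compounds shown leave open whether a single chlorine on the aryl group would hold this level. As far as these compounds go, how a trifluoromethyl or nitrile group on that ring would read also remains open.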